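From isoquinolin-4-yl to quinolin-4-yl on the carbonyl carbon

The source may report more compounds than this note shows. Statements on the series, on what has been measured and on what is new or still open speak of the compounds shown alone.

Measured in an ADME assay on the whole organism (strain ICR) for pharmacokinetics, with Mus musculus as the target, using cassette dosing, with a stated time of 8 h, at a dose of 1 mg/kg by the oral route; on this read-out higher numbers stand for higher exposure at the dose given and lower numbers for lower exposure:
- compound 1 `O=C(c1c[nH]c(=O)c2ccccc12)N1CCN(C(=O)c2ccc(Br)cc2)[C@@H](c2ccc(Cl)cc2)C1`: 97.3 ng.h/mL
- compound 2 `O=C(c1cncc2ccccc12)N1CCN(C(=O)c2ccc(Br)cc2)[C@@H](c2ccc(Cl)cc2)C1`: 1.5 ng.h/mL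
- compound 3 `O=C(c1cnn2cc(Br)ccc12)N1CCN(C(=O)c2ccc(Br)cn2)[C@@H](c2ccc(Cl)cc2)C1`: 55.9 ng.h/mL

In this assay compound 2 stands lowest of the three at 1.5 ng.h/mL, and compound 1 and compound 3 both lie higher, beyond the scatter. Compound 4 `O=C(c1ccnc2ccccc12)N1CCN(C(=O)c2ccc(Br)cc2)[C@@H](c2ccc(Cl)cc2)C1` has not yet been measured. Its structure departs from compound 2 as follows: quinolin-4-yl in place of isoquinolin-4-yl on a carbonyl carbon.

For the measured compounds named here, no measured step exchanges these two groups. The nearest evidence is a 65-fold lower number from compound 1 to compound 2 (1.81 log units; beyond the scatter), a large step at the same place, though it involves a different group. Going by the values given here, it shows only that the number can move strongly with a change there. Compound 3 reaches 55.9 ng.h/mL, but it differs in more than one place, so it offers only loose guidance. With compound 2 at 1.5 ng.h/mL, a rise seems more likely than a fall. The expected change is a 3.3-fold higher number from compound 2 to compound 4 (0.52 log units; beyond the scatter), a modest and uncertain rise. For compound 4 the estimated value is 5 ng.h/mL, with an expected range of 1 ng.h/mL to 30 ng.h/mL.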

Compound 4, area under the concentration-time curve in the Mus musculus assay: 129 ng.h/mL
The estimate for compound 4 lay 26-fold (1.41 log units) below the measured number, outside the stated range (above it).
By their numbers in the Mus musculus assay, from the lowest: compound 2; then compounds 3, 1 and 4 (each within the scatter of the next, the first and the last beyond it).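

In the Mus musculus assay compound 2 gives 1.5 ng.h/mL and compound 4 gives 129 ng.h/mL. In the Mus musculus assay, quinolin-4-yl in place of isoquinolin-4-yl on the carbonyl carbon gives an 86-fold higher number from compound 2 to compound 4 (1.93 log units; beyond the scatter), so two groups with the same atoms and the same counts of donors and acceptors, joined differently, can lie far apart at this place. In a physicochemical assay for solubility, at pH 6.8 (on this read-out lower numbers stand for lower solubility and higher numbers for higher solubility), compound 2 gives 5.1 ug/mL and compound 4 gives 3.2 ug/mL. For the compounds shown here, in the physicochemical assay the same exchange gives only a 1.6-fold lower number from compound 2 to compound 4 (0.20 log units; within the scatter), so that read-out shows no counterpart to the gap in exposure. Back in the Mus musculus assay, the group of compound 1 gives way to quinolin-4-yl with a 1.3-fold higher number from compound 1 to compound 4 (0.12 log units; within the scatter), which leaves compound 2 as the low one of these three compounds, not the group of compound 1 as the high one.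

Nothing measured here explains the gap. As far as these compounds go, it also stays open whether quinolin-4-yl keeps its number when it carries an added amine or carboxylic acid, or when the bromophenyl carbonyl group of the core is exchanged.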